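This account rests on a few compounds, and the source may have more. Where it says the series, first, only, none or still open, it means among the compounds named here.

Notes on the series, with compound 2 as the starting point. In an ADME assay on MRC5 cells (Homo sapiens) for cytotoxicity, read by resazurin assay, with a stated time of 72 h (on this read-out lower numbers stand for stronger inhibition and higher numbers for weaker inhibition), compound 2 (`CC1(COc2cccc(-c3ccc(F)cc3)n2)CCn2cc([N+](=O)[O-])nc2O1`) gives > 64000 nM, which is a limit and not a number. Compound 1 (`O=[N+]([O-])c1cn2c(n1)OC(COc1cccc(-c3ccc(F)nc3F)n1)CC2`) gives > 64000 nM, also a limit. Compound 2 therefore has no exact value to stand on, and the picture so far is the limit of > 64000 nM in this assay, at which 2 of the 2 values shown sit.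

Compound 3 (`O=[N+]([O-])c1cn2c(n1)OC(COc1cccc(-c3ccc(F)cc3)n1)CC2`) differs from compound 2 in one place, hydrogen in place of methyl on a saturated ring carbon, next to the ring oxygen.

For the measured compounds named here, no step between measured compounds is available, so the expectation rests on compound 2 and its limit of > 64000 nM. The expected step, a number no higher from compound 2 to compound 3 (the limit leaves the size open), is none beyond the scatter in this assay. For compound 3 the estimate is 64000 nM, with an expected range of 30000 nM to 64000 nM.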

Compound 3, half-maximal inhibitory concentration: 59000 nM
For compound 3 the middle estimate is 1.1-fold (0.04 log units) above the measured one; the measured number falls inside the stated range.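

For the compounds shown here, compound 3 is the first compound here with an exact number in this assay, so this ring carbon and the aryl group now have a real value on one side of each comparison. Hydrogen in place of methyl on a saturated ring carbon, next to the ring oxygen, gives an at least 1.0-fold lower number from compound 2 to compound 3 (0.03 log units; that floor lies within the scatter), and 4-fluorophenyl in place of 2,6-difluoropyridin-3-yl on an aromatic carbon gives an at least 1.0-fold lower number from compound 1 to compound 3 (0.03 log units; that floor lies within the scatter). Neither change is shown to move the number beyond the scatter, and the true size of both steps stays unread, as the other end of each rests on a limit: the limit of > 64000 nM in this assay, at which 2 of the 3 values shown sit.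

As far as these compounds go, what an ethyl group or a longer chain does at this saturated ring carbon stays open. So does the effect of an amine or a carboxylic acid on the aryl group.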